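Working notes: carbonyl substituent series, compound 2 to compound 3

The source may report more compounds than this note shows. Statements on the series, on what has been measured and on what is new or still open speak of the compounds shown alone.

The series shares a long branched chain ending in a conjugated carbonyl group, and only the group on that carbonyl carbon is varied. Compound 1 `CC(/C=C/CC(C)CCCC(C)C)=C\C(=O)O` carries a hydroxy there and gives 5.95 in a physicochemical assay for lipophilicity; a higher number here means a more lipophilic compound, a lower number a more polar compound. Going by the values given here, compound 2 `CSC(=O)/C=C(C)/C=C/CC(C)CCCC(C)C` carries a methylsulfanyl instead and gives 7.44; this is the higher of the two numbers measured so far, with the change a number 1.49 log units higher from compound 1 to compound 2 (beyond the scatter). Compound 3 `CCN(CC)C(=O)/C=C(C)/C=C/CC(C)CCCC(C)C` is the next member, not yet measured. (diethylamino in place of methylsulfanyl on a carbonyl carbon). Among the compounds with values here, the only measured step so far, a number 1.49 log units higher from compound 1 to compound 2 (beyond the scatter), concerns the same carbonyl carbon but a different pair of groups, so it bears on the present step only in showing that this position moves the read-out by a large amount. Within the data shown here, no measured pair shows a diethylamino anywhere, so the direction must be judged from the shape of the change alone. For compound 3 a downward step is expected, a number 0.74 log units lower from compound 2 to compound 3 (beyond the scatter), leaving it between compound 1 and compound 2. Compound 3 is thus estimated at 6.7, with a range from 6 to 7.4.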

Compound 3, partition coefficient: 6.02
Estimate against measurement, compound 3: 0.68 log units above; the measured number falls inside the stated range.
By their numbers in this assay, from the lowest: compounds 1 and 3 (each within the scatter of the next); then compound 2.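

In this assay, going by these compounds alone, this carbonyl carbon turns out to move the read-out in both directions: the one earlier step went up, whereas diethylamino in place of methylsulfanyl gives a large step down (a number 1.42 log units lower from compound 2 to compound 3 (beyond the scatter)). Diethylamino and hydroxy on this carbon cannot be told apart (a number 0.07 log units higher from compound 1 to compound 3 (within the scatter)), so of the three groups shown, only methylsulfanyl stands clear of the others, with compound 2 beyond the scatter of both compound 1 and compound 3. No measurement on hand accounts for the size of either step or for the closeness of compound 1 and compound 3.

The compounds shown leave open whether the high number of compound 2 belongs to the sulfur itself or would also appear with a methoxy on the same carbonyl carbon, a group that would differ from methylsulfanyl in that one atom. They also leave open whether the number seen with diethylamino holds for a smaller amine such as dimethylamino, for a primary amide, or for a ring amine such as pyrrolidine at this carbon.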